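From cyano to dimethylamino on the shared core

A few compounds are considered here, and "the series" means these few. Any claim that something is new, unique, unknown or untested is made for them only; others in the source may bear on it.

Compound 1 `O=C(CCCCCCC(=O)Nc1ccc(O)cc1)NO` gives 15000 nM
Compound 2 `N#Cc1ccc(NC(=O)CCCCCCC(=O)NO)cc1` gives 42000 nM
Compound 3 `CN(C)c1ccc(NC(=O)CCCCCCC(=O)NO)cc1` is not yet measured

For the measured compounds named here, in a functional assay on HT-29 cells (Homo sapiens) for antiproliferative activity, with a stated time of 48 h (on this read-out higher numbers stand for an effect only at larger amounts of compound and lower numbers for an effect already at smaller amounts), compound 2 has the higher of the two numbers (42000 nM), and compound 1 is its only neighbour. Compound 3 carries dimethylamino in place of cyano on an aromatic carbon. Going by the values given here, one measured step bears on this carbon: cyano in place of hydroxy gave a 2.8-fold higher number from compound 1 to compound 2 (0.45 log units; beyond the scatter) and is a modest change. Among the compounds with values here, no measured compound shows what dimethylamino itself does, so any forecast is uncertain. Removing the cyano might undo part of that step, so a modest move toward a lower number is expected in this assay rather than a large one. The expected change is a 1.9-fold lower number from compound 2 to compound 3 (0.28 log units; within the scatter) and remains tentative. For compound 3 the estimated value is 22000 nM with an expected range from 8000 nM to 55000 nM as a guide.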

Compound 3, half-maximal effective concentration: 3150 nM
Estimate against measurement, compound 3: 7.0-fold (0.84 log units) above, outside the stated range (below it).
By their numbers in this assay, from the lowest: compound 3; then compound 1; then compound 2.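

In this assay, for the compounds shown here, the group on this aromatic carbon, para to a large group, turns out to matter far more than the single earlier step suggested: dimethylamino in place of cyano gives a 13-fold lower number from compound 2 to compound 3 (1.12 log units; beyond the scatter) and counts as a large change. Set against hydroxy, dimethylamino gives a 4.8-fold lower number from compound 1 to compound 3 (0.68 log units; beyond the scatter) as well, so the new group does more than recover the level of compound 1 and goes past it, which makes compound 3 the lowest of the three numbers. Nothing measured here explains why dimethylamino behaves this way.

A plain amine or a methoxy group on the same carbon would show whether the low number belongs to dimethylamino alone or is shared with other groups. From the compounds shown here alone, it also remains open whether this gain would hold on a shorter or longer chain, as all three compounds carry the same one.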